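Amino in place of chloro at the inactive limit

The source may hold more compounds than are shown below. What is called first, only, known or untested is meant among the compounds shown, and "the series" means these compounds.

Compound 1, `Fc1ccc2nc(-c3ccccc3)nc(Nc3ccccc3)c2c1`, gives > 50000 nM in a functional assay on COLO 205 cells (Homo sapiens) for cytotoxicity, read by MTT assay, with a stated time of 48 h (a lower number here means a stronger inhibitor, a higher number a weaker inhibitor), which is a limit of the assay and not a number.
Compound 2, `Fc1cccc(-c2nc(Nc3ccccc3Cl)c3cc(F)ccc3n2)c1`, gives > 50000 nM in this assay, again a limit and not a number.

Among the measured compounds shown here, compound 2 thus stands at the edge of what this assay reports: its own value is a limit, and the one further value shown is a limit too, since both sit at the limit of > 50000 nM in this assay, at which 2 of the 2 values shown sit. For the measured compounds named here, no step between measured compounds can be stated. Neither compound gives a number. Compound 3, `Nc1ccccc1Nc1nc(-c2cccc(F)c2)nc2ccc(F)cc12`, differs from compound 2 in one place: amino in place of chloro on an aromatic carbon. With the two shown values resting at the limit, there is no measured footing for a move in either direction, and the step is expected to be a number no higher from compound 2 to compound 3 (the limit leaves the size open), that is, nothing beyond the scatter. Compound 3 is therefore estimated at 50000 nM, with a range from 10000 nM to 150000 nM, and it is expected more likely than not that this assay will again report only a limit for compound 3.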

Compound 3, half-maximal inhibitory concentration: > 50000 nM
Compound 3 ended at the assay's limit; the forecaster's own chance of this, stated with the estimate: 65%; the middle value lies on the limit itself.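

Compound 3 gives > 50000 nM in this assay, again a limit and not a number, so no step from compound 2 to compound 3 can be read: the limit of > 50000 nM in this assay, at which 3 of the 3 values shown sit.

The compounds shown leave open whether amino in place of chloro changes the cytotoxicity at all, and what number any of the three compounds would give.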